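This account rests on a few compounds, and the source may have more. Where it says the series, first, only, none or still open, it means among the compounds named here.

Measured in a functional assay on MCF7 cells (Homo sapiens) for inhibition, read by MTT assay, with stated times of 18 h and 4 h; on this read-out higher numbers stand for weaker inhibition and lower numbers for stronger inhibition:
- compound 1 `CCCCCCCCCCCCCCCCOP(=O)(O)OCCSC(=S)N1CCCCCC1`: > 100000 nM (a limit of the assay, not a number)
- compound 2 `CCCCCCCCOP(=O)(O)OCCSC(=S)N1CCCC1`: 53000 nM
- compound 3 `CCCCCCCCOP(=O)(O)OCCSC(=S)N1CCN(C)CC1`: 46000 nM

Going by the values given here, compound 3 cannot be ranked against compound 2, as the only measured step between them, a 1.2-fold lower number from compound 2 to compound 3 (0.06 log units; within the scatter), does not separate them. Both carry an octyl chain and differ only in the ring group on the thiocarbonyl carbon.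

The next compound, compound 4 `CCCCCCCCOP(=O)(O)OCCSC(=S)N1CCCCCC1`, has azepan-1-yl in place of 4-methylpiperazin-1-yl on a thiocarbonyl carbon. A seven-membered non-aromatic ring thus replaces a six-membered one, and the count of hetero atoms falls.

Compound 1 also carries azepan-1-yl, but with a hexadecyl chain where compound 4 has octyl. Compound 1 reads only as a limit, > 100000 nM, so it gives no number to work from.

That leaves one measured swap of this ring group as a guide, and it was small: a 1.2-fold lower number from compound 2 to compound 3 (0.06 log units; within the scatter). In this assay, no change beyond the scatter is therefore expected, and no direction can be favoured. The expected change is a 1.1-fold lower number from compound 3 to compound 4 (0.04 log units; within the scatter). For compound 4 the estimated value is 42000 nM, with an expected range from 18000 nM to 95000 nM.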

Compound 4, half-maximal inhibitory concentration: 78000 nM
Beside the measured number, compound 4's estimate is 1.9-fold (0.27 log units) below it, within the range that was stated.
By their numbers in this assay, from the lowest: compounds 3, 2 and 4 (each within the scatter of the next). At a limit, above all of these: compound 1.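

In this assay, the octyl series now covers three ring groups on the thiocarbonyl carbon, and neither step to azepan-1-yl goes beyond the scatter: a 1.7-fold higher number from compound 3 to compound 4 (0.23 log units; within the scatter), and a 1.5-fold higher number from compound 2 to compound 4 (0.17 log units; within the scatter). Pyrrolidin-1-yl, 4-methylpiperazin-1-yl and azepan-1-yl therefore cannot be ranked in this assay, even though the new group brings a seven-membered ring and one hetero atom in place of a six-membered ring with two. Going by these compounds alone, compound 4 also gives the first comparison of chain length with the ring group held constant, but the hexadecyl compound supplies only a floor, and the hexadecyl and octyl chains cannot be ordered on this result: an at least 1.2-fold lower number from compound 1 to compound 4 (0.10 log units; that floor lies within the scatter).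

Going by these compounds, these three ring groups span only a limited range, so it remains open whether an aromatic ring such as phenyl, or an open-chain group such as diethylamino, on the thiocarbonyl carbon would move the number beyond the scatter. Within the data shown here, the effect of chain length also remains open, and an octyl and a dodecyl compound carrying the same ring group would give a first measured step on that question.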